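Selenocyanate on the acetyl of a trimethoxyphenyl anilide

The source may hold more compounds than are shown below. What is called first, only, known or untested is meant among the compounds shown, and "the series" means these compounds.

Compound 1 `COc1ccc(CN(C(C)=O)c2cc(OC)c(OC)c(OC)c2)cc1O` stands lowest of the two numbers available: in a functional assay on HCT-116 cells (Homo sapiens) for inhibition, read by MTT assay, with a stated time of 48 h (a lower number here means a stronger inhibitor, a higher number a weaker inhibitor), compound 1 gives 270 nM, while compound 2 `COc1ccc(CNc2cc(OC)c(OC)c(OC)c2)cc1Cl` gives 41700 nM in this assay. Compound 3 `COc1ccc(CN(C(=O)C[Se]C#N)c2cc(OC)c(OC)c(OC)c2)cc1O` differs from compound 1 by a group of 3 heavy atoms (1 carbon, 1 nitrogen, 1 selenium; no ring) in place of a hydrogen atom, on a saturated chain carbon bound to a carbonyl carbon. Going by the values given here, no measured pair shows the effect of this change, so the size of the step is uncertain. Compound 3 is expected to remain close to compound 1, with an estimated step of a 1.5-fold lower number from compound 1 to compound 3 (0.18 log units; within the scatter) at most modest in either direction. In this assay compound 3 is estimated at 180 nM, within 40 nM to 1000 nM.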

Compound 3, half-maximal inhibitory concentration: 310 nM
Compound 3: the middle estimate sits 1.7-fold (0.24 log units) below what was measured, and the stated range covers the measured number.
By their numbers in this assay, from the lowest: compounds 1 and 3 (each within the scatter of the next); then compound 2.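

In this assay, the step of a 1.1-fold higher number from compound 1 to compound 3 (0.06 log units; within the scatter) shows that a saturated chain carbon bound to a carbonyl carbon can carry this selenocyanate group in place of a hydrogen atom with no difference beyond the scatter. The earlier compounds shown here gave no view of this position, and compound 3 now shows that it accepts a group of 3 heavy atoms. No available evidence explains this result. The compounds shown leave open how a thiocyanate, an amine or a carboxylic acid would read on this carbon. They also leave open whether a longer chain between the carbonyl and the selenium would be accepted.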